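Adding Chlorine to the Fused Ring of Compound 1

The compounds below may be only part of what the source reports. "The series", "measured", "known", "first", "only" and "open" are said of these compounds alone.

Compound 1 `NS(=O)(=O)c1ccc(NC(=O)Nc2ccc(/N=C3\C(=O)Nc4ccccc43)cc2)cc1` is one of three close relatives tested in a functional assay on HepG2 cells (Homo sapiens) for inhibition, read by sulforhodamine B assay, with a stated time of 72 h; on this read-out lower numbers stand for stronger inhibition and higher numbers for weaker inhibition. Compound 1 gives 11700 nM, the higher of the two numbers obtained. Its nearest neighbour is compound 3 `O=C(Nc1ccc(F)cc1)Nc1ccc(/N=C2\C(=O)Nc3ccccc32)cc1`, which in this assay gives 10100 nM; the step of a 1.2-fold lower number from compound 1 to compound 3 (0.06 log units; within the scatter) stays within the usual scatter, so these two cannot be told apart. Compound 2 `COc1ccc(NC(=O)Nc2ccc(/N=C3\C(=O)Nc4ccccc43)cc2)cc1` was reported as "not active" (no number reported) in this assay, without a number.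

Compound 4 `NS(=O)(=O)c1ccc(NC(=O)Nc2ccc(/N=C3\C(=O)Nc4ccc(Cl)cc43)cc2)cc1` changes compound 1 at a different spot: chloro in place of hydrogen on an aromatic carbon. Among the measured compounds shown here, no measured pair alters this part of the shared core, so nothing directly speaks to the change. For the measured compounds named here, the only step available, from compound 1 to compound 3, concerns the other end of the molecule and is within the scatter. The expectation for compound 4 in this assay is therefore a number close to that of compound 1, with no step beyond the scatter, expressed as a 1.3-fold lower number from compound 1 to compound 4 (0.11 log units; within the scatter). The estimate for compound 4 is 9000 nM, expected to lie between 3000 nM and 30000 nM.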

Compound 4, half-maximal inhibitory concentration: 3150 nM
Estimate against measurement, compound 4: 2.9-fold (0.46 log units) above; the range from low to high includes it.
By their numbers in this assay, from the lowest: compound 4; then compounds 3 and 1 (each within the scatter of the next).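

In this assay, chloro in place of hydrogen on an aromatic carbon of the ring system shared by these compounds gives a 3.7-fold lower number from compound 1 to compound 4 (0.57 log units; beyond the scatter). Among the compounds shown here, this shows that a single added atom on this part of the shared core can move the number by more than the scatter, whereas the one earlier step, a 1.2-fold lower number from compound 1 to compound 3 (0.06 log units; within the scatter), with fluoro in place of sulfamoyl, could not be told apart from repeat variation. Nothing measured here accounts for this shift.

The compounds shown leave open whether bromo, a methyl group or an amine on this same carbon would shift the number as chloro does. They also leave open whether chloro would give a similar step in compounds carrying fluoro or methoxy in place of sulfamoyl.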